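The source may report more compounds than this note shows. Statements on the series, on what has been measured and on what is new or still open speak of the compounds shown alone.

Measured so far:
- compound 1 `COc1ccc(NC(=O)c2ccc(-c3ccc(C4=NC(C)ON4)cc3C)cc2)cc1N1CCN(C)CC1`: 16%
- compound 2 `CN1CCN(c2cccc3ccc(OCC(=O)N4CCN(c5ccccc5C#N)CC4)cc23)CC1`: 48%

Both numbers come from an assay on isolated protein for inhibition of 5-hydroxytryptamine receptor 1B (Homo sapiens); on this read-out higher numbers stand for larger maximal responses and lower numbers for smaller maximal responses. On them compound 2 stands highest of the two; the distance down to compound 1 lies beyond the usual scatter, so the order of the two is real on this read-out. Compound 2 is the closer reference for the next compound, compound 3 `CN1CCN(c2cccc3ccc(OCC(=O)N4CCN(c5cccc6ccccc56)CC4)cc23)CC1`, which has not yet been measured in this assay.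

The change from compound 2 to compound 3 is naphthalen-1-yl in place of 2-cyanophenyl on an amine nitrogen in a ring. Within the data shown here, no pair of measured compounds isolates this kind of change, so no measured step guides the expectation. The step from compound 2 to compound 3 in this assay is expected to be of modest size, a number 2 percentage points higher from compound 2 to compound 3 (within the scatter), with the direction uncertain and possibly within the scatter.

Compound 3 is estimated at 50% in this assay, with a range from 25% to 75%.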

Compound 3, largest response reached (Emax), in percent of the reference or control that the assay uses: < 10%
Compound 3 was reported as a limit; the forecaster's own chance of this, stated with the estimate: 2%; middle value at least 40 percentage points away from the limit.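

In this assay, naphthalen-1-yl in place of 2-cyanophenyl on an amine nitrogen in a ring gives a number at least 38 percentage points lower from compound 2 to compound 3 (beyond the scatter). Among these compounds, this is the first one-place comparison, and it shows that the maximal response on this read-out depends strongly on the group at this nitrogen, which the unrelated pair of compound 1 and compound 2 could not show. Compound 3 carries a limit and not a number, so the step has a bound and no exact size: the limit of < 10% in this assay, at which 1 of the 3 values shown sits.

The change removes the nitrile and adds a second aromatic ring in one move, and the compounds shown do not separate these two parts. On these data alone, how a plain phenyl or a 2-methoxyphenyl on the same nitrogen would read remains open.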